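Series notes: aryl ketone hydrazides in the fibroblast toxicity assay

The compounds below may be only part of what the source reports. "The series", "measured", "known", "first", "only" and "open" are said of these compounds alone.

Measured so far:
compound 1 `Cc1ccc(C(=O)c2cc(F)c(OCC(=O)NNC(=O)c3ccc(=O)oc3)c(Cl)c2)cc1` — 30800 nM
compound 2 `Cn1cnc(C(=O)NNC(=O)COc2c(F)cc(C(=O)c3ccc(Cl)cc3)cc2Cl)c1` — 90900 nM

In an ADME assay on NIH3T3 cells (Mus musculus) for cytotoxicity, read by trypan blue exclusion, with a stated time of 48 h (a higher number here means a weaker inhibitor, a lower number a stronger inhibitor), compound 2 gives 90900 nM, the highest of the two numbers recorded. The nearest neighbour is compound 1, which in this assay gives 30800 nM, a gap that lies beyond the usual scatter; the two compounds differ in more than one place, so no single change can be read from that gap.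

Compound 3 `Cc1ccc(C(=O)c2cc(F)c(OCC(=O)NNC(=O)c3cn(C)cn3)c(Cl)c2)cc1` is the next point. Relative to compound 2 the change is methyl in place of chloro on an aromatic carbon, with the remainder of the molecule kept as in compound 2. Among the measured compounds shown here, no step in the set isolates this exchange. The expectation is a step of modest size, if any, from compound 2 to compound 3, a 1.3-fold lower number from compound 2 to compound 3 (0.11 log units; within the scatter), most likely toward a lower number but not clearly beyond the scatter. For compound 3 the estimate in this assay is 70000 nM, with a range from 25000 nM to 200000 nM.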

Compound 3, half-maximal inhibitory concentration: 93800 nM
The estimate for compound 3 lay 1.3-fold (0.13 log units) below the measured number, within the range that was stated.
By their numbers in this assay, from the lowest: compound 1; then compounds 2 and 3 (each within the scatter of the next).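

In this assay the exchange of 4-chlorophenyl for 4-methylphenyl, on an aromatic carbon para to a large group, gives a 1.0-fold higher number from compound 2 to compound 3 (0.01 log units; within the scatter), so at this position compound 2 and compound 3 cannot be told apart. With the 4-methylphenyl group held constant, the change on the carbonyl carbon can now be read alone: the group with a five-membered aromatic ring in place of the group with a six-membered aromatic ring gives a 3.0-fold higher number from compound 1 to compound 3 (0.48 log units; beyond the scatter), a step beyond the scatter that places the difference at this site for this pair. No measurement in hand accounts for either step.

Only chloro and methyl are shown at the first position, so the outcome with an amine, a carboxylic acid or a longer chain there remains open. On these data alone, it also remains open whether the methyl and chloro exchange would read the same with the six-membered ring of compound 1 on the carbonyl carbon.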